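The source may report more compounds than this note shows. Statements on the series, on what has been measured and on what is new or still open speak of the compounds shown alone.

Measured so far:
- Compound 1 `Cc1cc(C(=O)O)ccc1CN1CCC[C@H](O[C@H](CO)c2ccnc(Cl)c2)[C@@H]1c1ccccc1`: > 200000 nM
- Compound 2 `Cc1cc(C(=O)O)ccc1CN1CCC[C@H](O[C@H](CO)c2cc(Cl)cc(Cl)c2)[C@@H]1c1ccccc1F`: "nd" (no result reported)
- Compound 3 `COC(=O)Nc1cc(C(=O)O)ccc1CN1CCC[C@H](O[C@H](CO)c2cc(Cl)cc(Cl)c2)[C@@H]1c1ccccc1`: 69000 nM

In an assay on isolated protein for activation of cGMP-dependent protein kinase 1 (Homo sapiens), read by ADP-Glo, with stated times of 30 min and 2 h (a higher number here means that more compound is needed for the effect, a lower number that less compound is needed), compound 1 reaches only the limit of the assay, > 200000 nM, which is a limit and not a measured number. Compound 1 therefore stands at the limit of > 200000 nM in this assay, at which 1 of the 3 values shown sits, and nothing more precise can be said of its own position. Compound 2 has no result in this assay, recorded as "nd" (no result reported). Compound 3 differs from compound 1 in several places. In this assay, among the measured compounds shown here, compound 3 gives 69000 nM, the only single number among the three.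

Compound 4 `Cc1cc(C(=O)O)ccc1CN1CCC[C@H](O[C@H](CF)c2cc(Cl)cc(Cl)c2)[C@@H]1c1ccccc1` is not yet measured. It differs from compound 1 in one place: a group of 11 heavy atoms (8 carbon, 1 fluorine, 2 chlorine; one six-membered aromatic ring of carbon only) in place of a group of 10 heavy atoms (7 carbon, 1 nitrogen, 1 oxygen, 1 chlorine; one six-membered aromatic ring with 1 hetero atom), on an oxygen on a saturated carbon. For the measured compounds named here, no step between two measured compounds that differ in a single place is available, so the size of this change has to be guessed from the three values alone. Going by the values given here, since compound 1 sits at a limit, the step cannot be read directly; the value of compound 3 gives the only hint of a number that the shared core can reach. This estimate means an expected step of an at least 2.0-fold lower number from compound 1 to compound 4 (0.30 log units; that floor lies within the scatter). Compound 4 is expected to give about 100000 nM, with a range from 30000 nM to 300000 nM, and a fair chance that only a limit is reported again.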

Compound 4, half-maximal effective concentration: 20000 nM
Estimate against measurement, compound 4: 5.0-fold (0.70 log units) above; the whole stated range lies above it.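

Among the compounds shown here, this is the first step in the set that can be read at a single place: on an oxygen on a saturated carbon, the group of 11 heavy atoms in place of the group of 10 heavy atoms gives an at least 10-fold lower number from compound 1 to compound 4 (1.00 log units; beyond the scatter) in this assay, so the read-out responds to what sits here. The group that enters carries 0 hydrogen-bond donors and 0 hydrogen-bond acceptors, and compound 4 still gives a single number, so neither is needed in this place for a measurable effect. The size of the step is only a floor, because compound 1 stands at a limit and not at a number: the limit of > 200000 nM in this assay, at which 1 of the 4 values shown sits.

The ring, the chlorine count and the rest of the group change together, so the compounds shown do not tell which part carries the step, and no step involving compound 2 or compound 3 can be read. Going by these compounds, whether an amine or a longer chain in this place would keep the lower number also stays open.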